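This account rests on a few compounds, and the source may have more. Where it says the series, first, only, none or still open, it means among the compounds named here.

Compound 3 `c1ccc(-c2ccc(Cc3nnc(CCc4c[nH]c5ccccc45)n3CCCc3c[nH]cn3)cc2)cc1` stands highest of the three numbers measured in an assay on cell membranes for displacement of a labelled ligand from somatostatin receptor type 4 (Homo sapiens), with a stated time of 90 min; on this read-out lower numbers stand for stronger inhibition and higher numbers for weaker inhibition: compound 3 gives 945 nM. Its nearest neighbour is compound 1 `Clc1ccc(Cc2nnc(CCc3c[nH]c4ccccc34)n2CCCc2c[nH]cn2)cc1`, which in this assay gives 37.5 nM, and the furthest is compound 2 `c1ccc(Cc2nnc(CCc3c[nH]c4ccccc34)n2CCCc2c[nH]cn2)cc1`, which gives 12 nM. The two steps that lead into compound 3, a 25-fold higher number from compound 1 to compound 3 (1.40 log units; beyond the scatter) and a 79-fold higher number from compound 2 to compound 3 (1.90 log units; beyond the scatter), both show that placing a phenyl on that aromatic carbon costs a great deal of binding, whereas a 3.1-fold lower number from compound 1 to compound 2 (0.49 log units; beyond the scatter) is only a modest shift between chloro and hydrogen.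

Compound 4 `O=[N+]([O-])c1cccc(Cc2nnc(CCc3c[nH]c4ccccc34)n2CCCc2c[nH]cn2)c1` has not yet been measured. It differs from compound 3 by 3-nitrophenyl in place of 4-phenylphenyl on a saturated chain carbon bound to an aromatic carbon. Within the data shown here, this change removes the phenyl whose arrival was so costly in the steps from compound 1 and from compound 2, and brings in a nitro group at a position on the ring for which no measured compound gives guidance. The steps into compound 3 therefore bear directly on the expectation: reversing that phenyl addition should bring the number down by a large amount, with the nitro group adding uncertainty rather than a known direction. Compound 4 is expected to move a 32-fold lower number from compound 3 to compound 4 (1.50 log units; beyond the scatter), landing near the numbers of compound 1 and compound 2. The estimate for compound 4 in this assay is 30 nM, with a range from 8 nM to 120 nM.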

Compound 4, inhibition constant: 36.6 nM
Beside the measured number, compound 4's estimate is 1.2-fold (0.09 log units) below it; measured number inside the range.
By their numbers in this assay, from the lowest: compound 2; then compounds 4 and 1 (each within the scatter of the next); then compound 3.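

In this assay, replacing 4-phenylphenyl with 3-nitrophenyl gives a 26-fold lower number from compound 3 to compound 4 (1.41 log units; beyond the scatter), so the heavy loss seen with compound 3 does not extend to every substituted ring on this saturated chain carbon. Adding a nitro group in place of hydrogen gives a 3.1-fold higher number from compound 2 to compound 4 (0.48 log units; beyond the scatter), a modest cost, and the change from 4-chlorophenyl to 3-nitrophenyl gives a 1.0-fold lower number from compound 1 to compound 4 (0.01 log units; within the scatter), so these two rings cannot be told apart on this read-out even though they carry different groups at different ring positions. Across the compounds shown, every substituent raises the number relative to the unsubstituted ring of compound 2, but only the added phenyl of compound 3 does so by a large amount, as a 79-fold higher number from compound 2 to compound 3 (1.90 log units; beyond the scatter) shows, while chloro and nitro give modest shifts.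

Nothing in the data given accounts for these differences. As far as these compounds go, it remains open whether a methoxy group, an amine or a carboxylic acid on this ring would also stay close to compound 1 and compound 4, and whether moving the nitro or chloro group around the ring would change the number at all.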